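Series notes: chloro to methyl swap on compound 1

This account rests on a few compounds, and the source may have more. Where it says the series, first, only, none or still open, it means among the compounds named here.

Measured compounds:
compound 1 `O=c1c(Cc2coc3cccc(OCC4CCCCC4)c3c2=O)coc2cc(Cl)ccc12` — > 10000 nM
compound 2 `CC(C)CCOc1cccc2occ(Cc3coc4ccccc4c3=O)c(=O)c12` — > 10000 nM

In a functional assay on HCT-15 cells (Homo sapiens) for antiproliferative activity, read by XTT assay (on this read-out higher numbers stand for weaker inhibition and lower numbers for stronger inhibition), compound 1 is reported only as a limit of the assay, > 10000 nM. Compound 2 is likewise reported only as a limit, > 10000 nM. Among the measured compounds shown here, both reports sit at the limit of > 10000 nM in this assay, at which 2 of the 2 values shown sit, so compound 1 stands at the edge of the measured range and no measured step places it against another compound.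

Compound 3 `Cc1ccc2c(=O)c(Cc3coc4cccc(OCC5CCCCC5)c4c3=O)coc2c1` differs from compound 1 by methyl in place of chloro on an aromatic carbon. For the measured compounds named here, no pair of measured compounds differs in one place, so the size of this step has no precedent in this assay. With compound 1 at its limit, no step beyond the scatter is expected, and compound 3 would most likely again be reported as a limit. Compound 3 is expected to give 15000 nM, within 5000 nM to 50000 nM. The expected step is a step that the limit leaves unreadable from compound 1 to compound 3, none beyond the scatter.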

Compound 3, half-maximal inhibitory concentration: 2220 nM
For compound 3 the middle estimate is 6.8-fold (0.83 log units) above the measured one; measured number outside the range, below it.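

In this assay, among the compounds shown here, methyl in place of chloro on an aromatic carbon gives an at least 4.5-fold lower number from compound 1 to compound 3 (0.65 log units; beyond the scatter), the first readable step. For the compounds shown here, compound 3, at 2220 nM, is the first compound here with a value inside the measured range, so a change at this position on the six-membered aromatic ring of carbon only can move the read-out while the rest of compound 1 stays the same. On these data alone, the full size of the step stays open, since it starts from a limit: the limit of > 10000 nM in this assay, at which 2 of the 3 values shown sit.

Open, as far as these compounds go, is whether this result is specific to methyl, or whether ethyl or methoxy at the same carbon would give a similar value. Also open, from the compounds shown here alone, is whether methyl at this carbon would give a value within the measured range on the core of compound 2.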